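Swapping Propoxy for Phenylsulfonylamino in a Channel Blocker Series

This account rests on a few compounds, and the source may have more. Where it says the series, first, only, none or still open, it means among the compounds named here.

Measured compounds:
compound 1, `Cc1cccnc1-c1ccc(C(=O)Nc2ccc(F)cc2)cc1`, > 4000 nM
compound 2, `CCCOc1cccnc1-c1ccc(C(=O)Nc2ccc(C(C)(C)C)cc2)cc1`, 20 nM

For the measured compounds named here, in a functional assay for antagonist activity at transient receptor potential cation channel subfamily V member 1 (Rattus norvegicus) (a lower number here means a stronger inhibitor, a higher number a weaker inhibitor), compound 2 gives 20 nM, the only real number measured here. Compound 1 reaches only a limit of the assay, > 4000 nM. That entry is a limit, not a number: the limit of > 4000 nM in this assay, at which 1 of the 2 values shown sits. Going by the values given here, no step between measured compounds is available.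

Compound 3, `CC(C)(C)c1ccc(NC(=O)c2ccc(-c3ncccc3NS(=O)(=O)c3ccccc3)cc2)cc1`, differs from compound 2 by (phenylsulfonyl)amino in place of propoxy on an aromatic carbon. Among the compounds with values here, with no measured step to lean on, the expected change from compound 2 to compound 3 is a modest weakening, a 3.0-fold higher number from compound 2 to compound 3 (0.48 log units; beyond the scatter). Compound 3 is estimated at 60 nM, between 10 nM and 400 nM.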

Compound 3, half-maximal inhibitory concentration: 166 nM
Compound 3: the middle estimate sits 2.8-fold (0.44 log units) below what was measured, within the range that was stated.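

In this assay, putting (phenylsulfonyl)amino in place of propoxy on the aromatic carbon two atoms from the ring nitrogen gives an 8.3-fold higher number from compound 2 to compound 3 (0.92 log units; beyond the scatter). This position therefore accepts a larger group with its own aromatic ring and a hydrogen-bond donor at a modest cost, and compound 3 still gives a real number, 166 nM. Nothing measured here shows which feature of the new group accounts for the step. Still open, from the compounds shown here alone, is whether a plain amine on this carbon, or a methylsulfonylamino group without the added ring, would stay closer to compound 2 .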